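Swapping the acyl arm of a weak melanocortin-4 binder

The source may hold more compounds than are shown below. What is called first, only, known or untested is meant among the compounds shown, and "the series" means these compounds.

Three piperazine amides built on the shared core of compound 1 `COc1cc(Cl)ccc1C[C@@H](C)C(=O)N1CCN(c2ccc(C)cc2[C@@H](N)CC(C)C)CC1` have been measured in an assay on HEK293 cells for displacement of a labelled ligand from Melanocortin receptor 4 (Homo sapiens); on this read-out lower numbers stand for stronger inhibition and higher numbers for weaker inhibition. Compound 1 gives 8.1 nM, while compound 3 `CC(C)C[C@H](N)c1ccccc1N1CCN(C(=O)[C@H](C)Cc2ccc(Cl)cc2F)CC1` gives 67 nM in this assay. Compound 2 `CC(C)C[C@H](N)c1cc(C(F)(F)F)ccc1N1CCN(C(=O)COc2cccc(Cl)c2Cl)CC1` gives 2500 nM in this assay, the highest of the three numbers; its distance to compound 3, the nearest, and to compound 1, the furthest, both lie beyond the usual scatter, so compound 2 stands as the weakest binder of the set.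

Compound 4 `CC(C)C[C@H](N)c1cc(C(F)(F)F)ccc1N1CCN(C(=O)C(C)Cc2ccc(Cl)cc2)CC1` has not yet been measured. It keeps the core of compound 2 with its trifluoromethyl group and changes only the acyl arm: 1-(4-chlorobenzyl)ethyl in place of (2,3-dichlorophenoxy)methyl on a carbonyl carbon. The new arm resembles the arms carried by compound 1 and compound 3, both of which give far lower numbers than compound 2, though compound 4 lacks the ring fluorine of compound 3 and carries no defined stereochemistry at the substituted carbon.

The step from compound 2 to compound 4 is expected to be a large fall in the number, a 17-fold lower number from compound 2 to compound 4 (1.22 log units; beyond the scatter), well beyond the scatter. Compound 4 is therefore estimated at 150 nM in this assay, with a range from 30 nM to 700 nM.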

Compound 4, inhibition constant: 47 nM
Compound 4: the middle estimate sits 3.2-fold (0.50 log units) above what was measured, within the range that was stated.
By their numbers in this assay, from the lowest: compound 1; then compounds 4 and 3 (each within the scatter of the next); then compound 2.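

Going by these compounds alone, the step of a 53-fold lower number from compound 2 to compound 4 (1.73 log units; beyond the scatter) in this assay is the first in the set that isolates a single place, and it shows that the group on the carbonyl carbon alone moves the number by a large margin while the core of compound 2, with its trifluoromethyl group, stays unchanged. Compound 4 gives 47 nM on that same core, so the high number of compound 2 cannot be laid to the trifluoromethyl-bearing core alone, and the two arms show that a matching count of heavy atoms and one aromatic ring of carbon do not by themselves set the value. No measurement shown here offers an explanation for the size of this step.

The change swaps several features at once, the ether oxygen, the second chlorine and the branching methyl, so a (4-chlorophenoxy)methyl arm or a 2,3-dichlorobenzyl arm on this core would be needed to tell these apart. From the compounds shown here alone, compound 4 also has no defined stereochemistry at the substituted carbon, so how its two separate forms compare remains open.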